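From methyl to (1H-pyrazol-3-yl)carbonyl: compound 3 to compound 4

A few compounds are considered here, and "the series" means these few. Any claim that something is new, unique, unknown or untested is made for them only; others in the source may bear on it.

Values measured so far in a physicochemical assay for lipophilicity, read by HPLC, measured as chromatographic lipophilicity, at pH 7.4 (a higher number here means a more lipophilic compound, a lower number a more polar compound), for the series
compound 1 `O=C(c1cccnc1)N1CCC(C(=O)N2N=CCC2c2ccccc2)CC1` 2.6
compound 2 `O=C(C1CCN(c2ccccc2)CC1)N1N=CCC1c1ccccc1` 6.3
compound 3 `CN1CCC(C(=O)N2N=CCC2c2ccccc2)CC1` 1.1

Compound 3 stands lowest of the three numbers, and compound 2 lies furthest from it. Compound 4 (`O=C(c1cc[nH]n1)N1CCC(C(=O)N2N=CCC2c2ccccc2)CC1`) has (1H-pyrazol-3-yl)carbonyl in place of methyl on an amine nitrogen in a ring and is so far unmeasured. The closest measured precedent is the exchange between methyl and (pyridin-3-yl)carbonyl at that nitrogen, seen as a number 1.50 log units lower from compound 1 to compound 3 (beyond the scatter) and running opposite to the step considered here. The phenyl comparisons, a number 3.70 log units higher from compound 1 to compound 2 (beyond the scatter) and a number 5.20 log units lower from compound 2 to compound 3 (beyond the scatter) as steps, bear less directly, with no carbonyl on that nitrogen in compound 2. For the measured compounds named here, no measured compound carries the (1H-pyrazol-3-yl)carbonyl group, so the precedent is only approximate. In this assay a rise of similar size, beyond the scatter, is therefore expected. The estimated change is a number 1.40 log units higher from compound 3 to compound 4 (beyond the scatter) in this reading. For compound 4 the estimated value is 2.5 with 1.9 to 3.1 as the expected range.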

Compound 4, distribution coefficient: 2.4
The estimate for compound 4 lay 0.10 log units above the measured number, and the stated range covers the measured number.
By their numbers in this assay, from the lowest: compound 3; then compounds 4 and 1 (each within the scatter of the next); then compound 2.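

In this assay, the (1H-pyrazol-3-yl)carbonyl group on the amine nitrogen in a ring reads like the (pyridin-3-yl)carbonyl group: the exchange of the two rings on the carbonyl carbon gives a number 0.20 log units lower from compound 1 to compound 4 (within the scatter), so these two aromatic rings are not separated at this position. Methyl and phenyl on the same nitrogen remain well apart from the new group, with a number 1.30 log units higher from compound 3 to compound 4 (beyond the scatter) and a number 3.90 log units lower from compound 2 to compound 4 (beyond the scatter). In this set, an aromatic ring held on a carbonyl therefore reads differently from phenyl directly on that nitrogen.

Going by these compounds, whether this match extends to non-aromatic groups on the same carbonyl, such as a longer alkyl chain, a carboxylic acid or a primary amine, remains open. Nothing available accounts for the size of any of these steps.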